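The source may report more compounds than this note shows. Statements on the series, on what has been measured and on what is new or still open speak of the compounds shown alone.

In an ADME assay on CHO-K1 cells (Cricetulus griseus) for cytotoxicity, read by MTT assay, with a stated time of 24 h (a lower number here means a stronger inhibitor, a higher number a weaker inhibitor), compound 1 `O=[N+]([O-])c1cc(-c2nnn(Cc3ccccc3F)n2)cc([N+](=O)[O-])c1` gives only a limit, > 200000 nM. Compound 2 `O=[N+]([O-])c1cc(-c2nnn(Cc3ccc(F)cc3)n2)cc([N+](=O)[O-])c1` gives 35000 nM, and compound 3 `COc1ccc(Cn2nnc(-c3cc([N+](=O)[O-])cc([N+](=O)[O-])c3)n2)cc1` gives 96000 nM, the highest of the two numbers; the nearest is compound 2, reached by a 2.7-fold higher number from compound 2 to compound 3 (0.44 log units; beyond the scatter) as methoxy replaces fluoro. Compound 4 `O=[N+]([O-])c1cc(-c2nnn(Cc3ccc(Cl)c(Cl)c3)n2)cc([N+](=O)[O-])c1` differs from compound 3 by 3,4-dichlorophenyl in place of 4-methoxyphenyl on a saturated chain carbon bound to an aromatic nitrogen. Within the data shown here, three measured steps concern that same position: an at least 5.7-fold lower number from compound 1 to compound 2 (0.75 log units; beyond the scatter), an at least 2.0-fold lower number from compound 1 to compound 3 (0.31 log units; beyond the scatter) and a 2.7-fold higher number from compound 2 to compound 3 (0.44 log units; beyond the scatter). Each swap there moved this assay by a modest amount, and the fluoro-bearing compound 2 sits lower than the methoxy-bearing compound 3. A modest lowering is therefore expected, a 2.4-fold lower number from compound 3 to compound 4 (0.38 log units; beyond the scatter). Compound 4 is estimated at 40000 nM, within 15000 nM to 120000 nM.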

Compound 4, half-maximal inhibitory concentration: 37000 nM
Compound 4: middle estimate off by 1.1-fold (0.03 log units), on the high side; measured number inside the range.
By their numbers in this assay, from the lowest: compounds 2 and 4 (each within the scatter of the next); then compound 3. At a limit, above all of these: compound 1.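

In this assay, the dichloro ring gives a 2.6-fold lower number from compound 3 to compound 4 (0.41 log units; beyond the scatter), so a second halogen-bearing group, not only 4-fluorophenyl, sits lower than 4-methoxyphenyl at this position. Set against 4-fluorophenyl, the change gives a 1.1-fold higher number from compound 2 to compound 4 (0.02 log units; within the scatter), so adding a second halogen and exchanging fluoro for chloro leaves the number level. The step of an at least 5.4-fold lower number from compound 1 to compound 4 (0.73 log units; beyond the scatter) starts from a limit rather than a number: the limit of > 200000 nM in this assay, at which 1 of the 4 values shown sits.

The compounds shown leave open how 3-chlorophenyl or 4-chlorophenyl alone would stand. They also leave open what an amine or a carboxylic acid on this ring, or a longer chain at this position, would do.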